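A few compounds are considered here, and "the series" means these few. Any claim that something is new, unique, unknown or untested is made for them only; others in the source may bear on it.

Of the compounds shown here, three sharing one core have been measured in an assay on membranes from brain for displacement of a labelled ligand from Neuronal acetylcholine receptor; alpha4/beta2 (Rattus norvegicus); a higher number here means a weaker inhibitor, a lower number a stronger inhibitor. Compound 1 `CN1CCC[C@H]1COc1cccnc1` gives 0.15 nM, compound 2 `Cc1cncc(OC[C@@H]2CCCN2C)c1` gives 0.48 nM, and compound 3 `CCCCc1cncc(OC[C@@H]2CCCN2C)c1` gives 0.16 nM. Compound 3 thus sits with compound 1, the two separated only by a 1.1-fold higher number from compound 1 to compound 3 (0.03 log units; within the scatter), and stands apart from compound 2 by a 3.0-fold lower number from compound 2 to compound 3 (0.48 log units; beyond the scatter). Compound 4 `CCCc1cncc(OC[C@@H]2CCCN2C)c1` has not yet been measured. It differs from compound 3 in that (hydrogen in place of methyl on a saturated chain carbon, three bonds along the chain from an aromatic carbon). For the measured compounds named here, three measured steps bear on this change: a 3.2-fold higher number from compound 1 to compound 2 (0.51 log units; beyond the scatter), a 1.1-fold higher number from compound 1 to compound 3 (0.03 log units; within the scatter) and a 3.0-fold lower number from compound 2 to compound 3 (0.48 log units; beyond the scatter). Together they show that methyl on the aromatic carbon gives a weaker inhibitor than either hydrogen or butyl, while butyl and hydrogen cannot be told apart; propyl lies between methyl and butyl in length, and nothing measured shows where between them its number will fall. The expected step is therefore a 1.6-fold higher number from compound 3 to compound 4 (0.19 log units; within the scatter), a modest drift toward the side of compound 2. Compound 4 is estimated at 0.25 nM, with a range from 0.1 nM to 0.7 nM.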

Compound 4, inhibition constant: 0.12 nM
For compound 4 the middle estimate is 2.1-fold (0.32 log units) above the measured one, within the range that was stated.
By their numbers in this assay, from the lowest: compounds 4, 1 and 3 (each within the scatter of the next); then compound 2.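

In this assay, propyl on the aromatic carbon cannot be told apart from butyl (a 1.3-fold lower number from compound 3 to compound 4 (0.12 log units; within the scatter)) or from hydrogen (a 1.3-fold lower number from compound 1 to compound 4 (0.10 log units; within the scatter)), so removing this methyl from the end of the butyl chain makes no difference that can be read. Methyl alone now stands apart, and it does so from propyl as well (a 4.0-fold lower number from compound 2 to compound 4 (0.60 log units; beyond the scatter)); among the compounds shown, the weaker number belongs only to compound 2, and the two longer chains do not share it. Nothing measured here explains why methyl differs from hydrogen, propyl and butyl.

Ethyl on this aromatic carbon lies outside the compounds shown, so the chain length at which the number returns to the level of compound 1 stays open. Also open, going by these compounds, is whether a longer chain than butyl, or an amine or a carboxylic acid at the end of the chain, would hold that level.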